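Compound 1 to compound 4: same atoms, joined differently

A few compounds are considered here, and "the series" means these few. Any claim that something is new, unique, unknown or untested is made for them only; others in the source may bear on it.

Among the compounds with values here, in a functional assay on B16 cells (Mus musculus), read by spectrophotometry, with a stated time of 3 days (a lower number here means a stronger inhibitor, a higher number a weaker inhibitor), compound 1 `CNC(=S)N/N=C/c1cccc2ccccc12` gives 2000 nM, the highest of the three numbers so far and so the weakest inhibitor of the three. Compound 2 `S=C(N/N=C/c1cccc2ccccc12)Nc1ccccc1` gives 500 nM, and compound 3 `Cc1ccccc1NC(=S)N/N=C/c1cccc2ccccc12` gives 490 nM.

Compound 4 `CN(/N=C/c1cccc2ccccc12)C(N)=S`, not yet measured, holds the same atoms as compound 1, joined differently: a group of 5 heavy atoms (2 carbon, 2 nitrogen, 1 sulfur; no ring) in place of a group of 5 heavy atoms (2 carbon, 2 nitrogen, 1 sulfur; no ring), on a double-bonded nitrogen.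

Within the data shown here, no measured step covers this kind of change. The nearest evidence is a 4.0-fold lower number from compound 1 to compound 2 (0.60 log units; beyond the scatter), with phenyl in place of methyl on an amide-type nitrogen, and a 4.1-fold lower number from compound 1 to compound 3 (0.61 log units; beyond the scatter), with 2-methylphenyl in the same place. Both are modest and beyond the scatter, while a 1.0-fold lower number from compound 2 to compound 3 (0.01 log units; within the scatter) stays within it. The entering group has no ring, so neither lowering is expected to carry over. A modest move towards a higher number is expected, held with little confidence.

The estimated step is a 1.5-fold higher number from compound 1 to compound 4 (0.18 log units; within the scatter). Compound 4 is expected at 3000 nM, with an estimated range from 900 nM to 12000 nM.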

Compound 4, half-maximal inhibitory concentration: 1600 nM
For compound 4 the middle estimate is 1.9-fold (0.27 log units) above the measured one, and the stated range covers the measured number.
By their numbers in this assay, from the lowest: compounds 3 and 2 (each within the scatter of the next); then compounds 4 and 1 (each within the scatter of the next).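

Rejoining the same atoms on a double-bonded nitrogen, with 1 hydrogen-bond donor in the entering group against 2 in the group that leaves, gives in this assay a 1.3-fold lower number from compound 1 to compound 4 (0.10 log units; within the scatter). At this position, then, the connectivity of the group and that difference in donor count can both shift without separating the two compounds beyond the scatter, whereas the steps to the ring-bearing groups, a 4.0-fold lower number from compound 1 to compound 2 (0.60 log units; beyond the scatter) and a 4.1-fold lower number from compound 1 to compound 3 (0.61 log units; beyond the scatter), lie beyond it. No measurement here bears on why the rejoined group reads this way.

As far as these compounds go, it remains open whether phenyl or 2-methylphenyl would give a similar step when carried on the rejoined group of compound 4. Also open, from the compounds shown here alone, is how a longer chain such as butyl, or a carboxylic acid, would read at this position.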